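The source may hold more compounds than are shown below. What is called first, only, known or untested is meant among the compounds shown, and "the series" means these compounds.

Values in a functional assay on SMMC-7721 cells (Homo sapiens) for cytotoxicity, read by MTT assay, with a stated time of 24 h (on this read-out lower numbers stand for stronger inhibition and higher numbers for weaker inhibition), for the measured compounds
- compound 1 `O=C1/C(=C/c2cccc([N+](=O)[O-])c2)CN(S(=O)(=O)c2ccc(F)cc2)C/C1=C\c1cccc([N+](=O)[O-])c1` gives 3980 nM
- compound 2 `CC(=O)Nc1ccc(S(=O)(=O)N2C/C(=C\c3cccc([N+](=O)[O-])c3)C(=O)/C(=C/c3cccc([N+](=O)[O-])c3)C2)cc1` gives 8420 nM
- compound 3 `CC(=O)Nc1ccc(S(=O)(=O)N2C/C(=C\c3ccc(C#N)cc3)C(=O)/C(=C/c3ccc(C#N)cc3)C2)cc1` gives 7120 nM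

Compound 1 lies within the scatter of compound 3, while the gap to compound 2 goes beyond it, as a 2.1-fold higher number from compound 1 to compound 2 (0.33 log units; beyond the scatter) shows. Compound 2 and compound 3 also lie within the scatter of each other.

The next compound to read is compound 4 `COc1cc(/C=C2\CN(S(=O)(=O)c3ccc(F)cc3)C/C(=C\c3cccc([N+](=O)[O-])c3)C2=O)cc(OC)c1OC`, reached from compound 1 by 3,4,5-trimethoxyphenyl in place of 3-nitrophenyl on a double-bonded chain carbon bound to a double-bonded ring carbon, with 3,4,5-trimethoxyphenyl in place of 3-nitrophenyl. Within the data shown here, the only measured single-place step is the modest 2.1-fold higher number from compound 1 to compound 2 (0.33 log units; beyond the scatter), and it concerns acetamido in place of fluoro, a different place in the molecule. Among the measured compounds shown here, no measured compound carries 3,4,5-trimethoxyphenyl, so the data give no firm direction. In this assay a shift beyond the scatter is therefore not expected. The estimated step is a 1.3-fold higher number from compound 1 to compound 4 (0.10 log units; within the scatter) and it stays small. For compound 4 the expected value is 5000 nM, with an estimated range from 1800 nM to 14000 nM.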

Compound 4, half-maximal inhibitory concentration: 4900 nM
The estimate for compound 4 lay 1.0-fold (0.01 log units) above the measured number; low and high end bracket the measured number.
By their numbers in this assay, from the lowest: compounds 1, 4, 3 and 2 (each within the scatter of the next, the first and the last beyond it).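

In this assay, among these compounds, the replacement of 3-nitrophenyl by 3,4,5-trimethoxyphenyl on a double-bonded chain carbon bound to a double-bonded ring carbon gives a 1.2-fold higher number from compound 1 to compound 4 (0.09 log units; within the scatter) and is the first single-place step read at this position. Among the compounds shown here, the position therefore accepts a group with more heavy atoms and no nitrogen without a shift beyond the scatter, whereas the only earlier single-place step, a 2.1-fold higher number from compound 1 to compound 2 (0.33 log units; beyond the scatter), concerned acetamido in place of fluoro and lay elsewhere in the molecule. No evidence is available on what lies behind this result.

On these data alone, whether a phenyl group carrying a carboxylic acid or a dimethylamino group would also stay within the scatter at this position remains open. Also open, as far as these compounds go, is the outcome of replacing the remaining 3-nitrophenyl group of compound 4 by a second 3,4,5-trimethoxyphenyl group.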